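The source may report more compounds than this note shows. Statements on the series, on what has been measured and on what is new or still open speak of the compounds shown alone.

Two ureas built on the same core have been measured. Compound 1 `CN(C)CCCNC(=O)Nc1cc2c(Nc3ccc(F)c(Cl)c3)ncnc2cc1O[C@H]1CCOC1` gives 226 nM in a functional assay on A-431 cells (Homo sapiens) for antiproliferative activity, read by sulforhodamine B assay, with a stated time of 72 h; a lower number here means a stronger inhibitor, a higher number a weaker inhibitor. For the measured compounds named here, compound 2 `O=C(Nc1cc2c(Nc3ccc(F)c(Cl)c3)ncnc2cc1O[C@H]1CCOC1)N1CC(O)C1` gives 1930 nM in this assay, which is the higher of the two numbers; the step of an 8.5-fold higher number from compound 1 to compound 2 (0.93 log units; beyond the scatter) is the only measured change at the carbonyl carbon. Compound 3 `O=C(Nc1cc2c(Nc3ccc(F)c(Cl)c3)ncnc2cc1O[C@H]1CCOC1)N1CCC(F)(F)CC1` differs from compound 2 by 4,4-difluoropiperidin-1-yl in place of 3-hydroxyazetidin-1-yl on a carbonyl carbon. Going by the values given here, no measured step exchanges one cyclic amine for another at this position, so the single step from compound 1 to compound 2 bears only indirectly on it; it shows that the group on the carbonyl carbon can move the number in this assay by a modest amount. For compound 3 the expected step of a 1.0-fold higher number from compound 2 to compound 3 (0.02 log units; within the scatter) is therefore small, with no clear direction beyond the scatter. Compound 3 is estimated at 2000 nM in this assay, within a range from 600 nM to 6500 nM.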

Compound 3, half-maximal inhibitory concentration: 1860 nM
Beside the measured number, compound 3's estimate is 1.1-fold (0.03 log units) above it; the measured number falls inside the stated range.
By their numbers in this assay, from the lowest: compound 1; then compounds 3 and 2 (each within the scatter of the next).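

In this assay, 4,4-difluoropiperidin-1-yl in place of 3-hydroxyazetidin-1-yl on the carbonyl carbon gives a 1.0-fold lower number from compound 2 to compound 3 (0.02 log units; within the scatter), so these two cyclic amines read alike at this position despite their different ring sizes and hydrogen-bond donor counts. Against the (3-(dimethylamino)propyl)amino group, the new ring gives an 8.2-fold higher number from compound 1 to compound 3 (0.92 log units; beyond the scatter), so the gap first seen with compound 2 now appears with a second cyclic amine. No evidence given here accounts for these numbers.

The compounds shown leave open whether a 4-(dimethylamino)piperidin-1-yl group on the carbonyl carbon would read nearer compound 1 or nearer compound 3. They also leave open whether the lower number of compound 1 goes with its open chain or with its terminal dimethylamino group, a question that a plain propylamino chain could address.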